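Restoring the ethenyl linker on the core of compound 3

A few compounds are considered here, and "the series" means these few. Any claim that something is new, unique, unknown or untested is made for them only; others in the source may bear on it.

Of the compounds shown here, three have been measured in an assay on a protein complex for inhibition of CDK8/Cyclin C (Homo sapiens), with a stated time of 1 h, tested at 10 uM; on this read-out lower numbers stand for less inhibition and higher numbers for more inhibition at the one concentration tested (going by the name of the read-out). Compound 1 `CCOC(=O)/C=C/c1ccncc1-c1ccc2c(cnn2C)c1` gives 100%, and compound 2 `O=C(/C=C/c1ccncc1-c1ccc2[nH]ccc2c1)N1CCOCC1` gives 97%. Compound 3 `NNC(=O)COc1ccncc1-c1ccc2ccccc2c1` stands lowest of the three: in this assay compound 3 gives 19%, a number far below that of compound 2 and even further below that of compound 1, both gaps lying beyond the scatter of the measurement. Among the compounds with values here, no step between compounds differing in a single place has been recorded, so the three numbers stand on their own.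

Compound 4 `COC(=O)/C=C/c1ccncc1-c1ccc2ccccc2c1` has not yet been measured. It keeps the core of compound 3 and differs from it in one place: 2-(methoxycarbonyl)ethenyl in place of (aminocarbamoyl)methoxy on an aromatic carbon. Within the data shown here, the group that enters in compound 4 is the one that compound 1 carries at the same place, and compound 1 gives 100% in this assay.

For this reason compound 4 is expected to move strongly upward in this assay, with a step of a number 74 percentage points higher from compound 3 to compound 4 (beyond the scatter). The estimate for compound 4 is 93%, with a range from 72% to 100%.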

Compound 4, a percentage reported as inhibition, at one concentration (the size of the read-out at that concentration, not a potency): 102%
Beside the measured number, compound 4's estimate is 9 percentage points below it, outside the stated range (above it).
By their numbers in this assay, from the lowest: compound 3; then compounds 2, 1 and 4 (each within the scatter of the next).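

In this assay, within the data shown here, placing 2-(methoxycarbonyl)ethenyl instead of (aminocarbamoyl)methoxy on the aromatic carbon opposite the ring nitrogen gives a number 83 percentage points higher from compound 3 to compound 4 (beyond the scatter), the first step that isolates a single place, so the low number of compound 3 can now be tied to the group at this position rather than to the rest of the molecule. The two groups have the same count of heavy atoms and neither has a ring, so the step does not come with a change in either count; the group that leaves carries nitrogen and hydrogen-bond donors, whereas the group that enters carries neither. No measurement at hand bears on why the number moves, so the step stands as an observation only.

On these data alone, what remains open is which part of the entering group matters, the ethenyl linker or the methyl ester, a question that a carboxylic acid or an amine-derived amide in place of the ester, or a saturated ethyl linker, would help to settle. As far as these compounds go, with a read-out at one concentration, and compound 4 at 102%, the potency of compound 4 also remains open.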